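This account rests on a few compounds, and the source may have more. Where it says the series, first, only, none or still open, it means among the compounds named here.

Measured compounds in a functional assay on NIH3T3 cells for agonist activity at Urotensin-2 receptor (Homo sapiens), with a stated time of 5 days; on this read-out higher numbers stand for an effect only at larger amounts of compound and lower numbers for an effect already at smaller amounts:
- compound 1 `CN(C)CCC(NC(=O)/C=C/c1ccc(C(F)(F)F)cc1)c1ccc2ccccc2c1` gives 135 nM
- compound 2 `CN(C)CCC(NC(=O)/C=C/c1ccccc1)c1ccc2ccccc2c1` gives 589 nM
- compound 3 `COc1ccc(/C=C/C(=O)NC(CCN(C)C)c2ccc3ccccc3c2)cc1` gives 380 nM

Compound 2 carries the highest number of the three. Its nearest neighbour is compound 3, with a 1.6-fold lower number from compound 2 to compound 3 (0.19 log units; within the scatter), a difference within the scatter, so no order between compound 2 and compound 3 can be stated. The furthest is compound 1, with a 4.4-fold higher number from compound 1 to compound 2 (0.64 log units; beyond the scatter), a modest step beyond the scatter; compound 1 against compound 3 shows a 2.8-fold higher number from compound 1 to compound 3 (0.45 log units; beyond the scatter), also modest.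

The next compound is compound 4 `CN(C)CCC(NC(=O)C#Cc1ccccc1)c1ccc2ccccc2c1`. It differs from compound 2 by 2-phenylethynyl in place of 2-phenylethenyl on a carbonyl carbon: the amide-bearing linker changes from an alkene to an alkyne, while the shared core and the unsubstituted phenyl ring remain.

None of the three measured steps bears on this change: all of them exchange a substituent on the aromatic ring and leave the linker untouched. There is therefore no measured guide to the size or direction of the step in this assay, and the expectation defaults to no change beyond the scatter, with a wide range to cover the untested move.

On that basis compound 4 is expected to give 700 nM (range 250 nM to 2000 nM), corresponding to an expected step of a 1.2-fold higher number from compound 2 to compound 4 (0.07 log units; within the scatter).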

Compound 4, half-maximal effective concentration: 457 nM
Compound 4: the middle estimate sits 1.5-fold (0.19 log units) above what was measured; the range from low to high includes it.
By their numbers in this assay, from the lowest: compound 1; then compounds 3, 4 and 2 (each within the scatter of the next).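

In this assay the change from 2-phenylethenyl to 2-phenylethynyl on the carbonyl carbon gives a 1.3-fold lower number from compound 2 to compound 4 (0.11 log units; within the scatter) and so shows no readable change. Among these compounds, this is the first look at the linker itself, as the earlier steps all exchanged a substituent on the aromatic ring, and for this pair the double bond can give way to a triple bond with no shift beyond the scatter, unlike the trifluoromethyl exchange, which gave a 4.4-fold higher number from compound 1 to compound 2 (0.64 log units; beyond the scatter) on the 2-phenylethenyl compounds. Nothing available gives a reason for this outcome or a measured property of either linker.

It remains open whether trifluoromethyl or methoxy on the aromatic ring of the 2-phenylethynyl compound would give steps like those seen with 2-phenylethenyl, since compound 4 is the only 2-phenylethynyl compound shown. Also open, as far as these compounds go, is how a fully saturated 2-phenylethyl chain, or a longer chain between the carbonyl carbon and the aromatic ring, would compare with these two linkers on the shared core.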